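The compounds below may be only part of what the source reports. "The series", "measured", "known", "first", "only" and "open" are said of these compounds alone.

Compound 3 `COc1ccc(-c2cccc3c(Cl)c(Br)c(C(F)(F)F)nc23)cc1` is one of three compounds tested in an assay for inhibition of ectonucleoside triphosphate diphosphohydrolase 2 (Homo sapiens), read by malachite green, with a stated time of 10 min; a lower number here means a stronger inhibitor, a higher number a weaker inhibitor. In this assay compound 3 gives only a limit of the assay, > 300000 nM. Compound 1 `FC(F)(F)c1nc2c(Br)cccc2c(Cl)c1Br` also gives a limit, > 300000 nM. Compound 2 `Fc1ccc(-c2c(C(F)(F)F)nc3c(-c4ccc(F)cc4)cccc3c2-c2ccc(F)cc2)cc1` likewise gives a limit, > 300000 nM. The step that the two limits leave unreadable from compound 1 to compound 3 therefore cannot be read, since both of its ends sit at the limit (the limit of > 300000 nM in this assay, at which 3 of the 3 values shown sit). Compound 4 `FC(F)(F)c1ccc(-c2cccc3c(Cl)c(Br)c(C(F)(F)F)nc23)cc1` differs from compound 3 by trifluoromethyl in place of methoxy on an aromatic carbon. Within the data shown here, no measured step bears on this change, and all three values shown rest at the same limit, so nothing beyond the scatter can be read into this assay for this step. Compound 4 is therefore expected to give 300000 nM, within 100000 nM to 1000000 nM, an expected step of a number no higher from compound 3 to compound 4 (the limit leaves the size open).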

Compound 4, half-maximal inhibitory concentration: > 300000 nM
Compound 4: no number, only a limit; the forecaster's own chance of this, stated with the estimate: 80%; the middle value lies on the limit itself.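

Neither compound 3 nor compound 4 gives a number in this assay, so the step between them cannot be read: the limit of > 300000 nM in this assay, at which 4 of the 4 values shown sit.

The compounds shown leave open which change to the shared core, if any, would give a measurable value in this assay.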